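The compounds below may be only part of what the source reports. "The series", "measured", "known", "first", "only" and "open" are said of these compounds alone.

Measured in an ADME assay on HepG2 cells (Homo sapiens) for cytotoxicity, read by fluorescence and resazurin assay, with a stated time of 24 h; on this read-out higher numbers stand for lower toxicity in this test and lower numbers for higher toxicity in this test:
- Compound 1 `O=S1(=O)C=C(Sc2nnc(C3CCCCC3)o2)c2ccccc21`: 15000 nM
- Compound 2 `O=S1(=O)C=C(Sc2nnc(-c3ccccc3Cl)o2)c2ccccc21`: 25000 nM
- Compound 3 `O=S1(=O)C=C(Sc2nnc(-c3ccccn3)o2)c2ccccc21`: 24000 nM

The value of compound 2 is 25000 nM, and it cannot be set apart from the other two values. The data show a 1.7-fold higher number from compound 1 to compound 2 (0.22 log units; within the scatter) and a 1.0-fold lower number from compound 2 to compound 3 (0.02 log units; within the scatter).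

The next compound to be tested is compound 4 `Cc1ccc(-c2nnc(SC3=CS(=O)(=O)c4ccccc43)o2)cc1`. It departs from compound 2 by a single change: 4-methylphenyl in place of 2-chlorophenyl on an aromatic carbon. The group concerned sits on an aromatic carbon of a five-membered aromatic ring with 2 nitrogen and 1 oxygen.

Among the compounds with values here, all the measured steps exchange the group on an aromatic carbon, so all of them bear on this change. Besides the two already given, there is a 1.6-fold higher number from compound 1 to compound 3 (0.20 log units; within the scatter). Cyclohexyl, 2-chlorophenyl and pyridin-2-yl thus gave values that lie within the scatter of one another. Within the data shown here, no measured compound carries 4-methylphenyl, so this is an expectation by analogy and not a direct reading. In this assay, no change beyond the scatter is expected. The expected step is a 1.2-fold lower number from compound 2 to compound 4 (0.08 log units; within the scatter), which is estimated to stay within the scatter. For compound 4 the estimated value is 21000 nM, with an expected range from 11000 nM to 40000 nM.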

Compound 4, half-maximal cytotoxic concentration: 31000 nM
The estimate for compound 4 lay 1.5-fold (0.17 log units) below the measured number, within the range that was stated.
By their numbers in this assay, from the lowest: compounds 1, 3, 2 and 4 (each within the scatter of the next, the first and the last beyond it).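

At this position, this assay gives a 1.2-fold higher number from compound 2 to compound 4 (0.09 log units; within the scatter) and a 1.3-fold higher number from compound 3 to compound 4 (0.11 log units; within the scatter), so 4-methylphenyl cannot be set apart from either 2-chlorophenyl or pyridin-2-yl. Within the data shown here, the new compound does supply the first step at this position that passes the scatter, a 2.1-fold higher number from compound 1 to compound 4 (0.32 log units; beyond the scatter), but this step is modest, and compound 2 and compound 3 each remain within the scatter of both of its end points, so the four groups form a continuous spread and not two separate levels. Nothing available explains even this small separation between 4-methylphenyl and cyclohexyl.

All four groups on this carbon are rings, which leaves open what an open chain such as n-butyl, or a phenyl ring carrying an amine or a carboxylic acid, would give in this test. As far as these compounds go, it also remains open whether the narrow spread seen so far reflects a general tolerance at this position or only the similarity of these four groups, and whether moving the methyl or the chlorine around the phenyl ring would matter.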